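Removing One Chloro from a Weak Anilide

The source may report more compounds than this note shows. Statements on the series, on what has been measured and on what is new or still open speak of the compounds shown alone.

Compound 3 `O=C(CNc1ccc(Cl)cc1Cl)N[C@H]1CCOC1=O` sits at the edge of what a functional assay on PC-3 cells (Homo sapiens) for antiproliferative activity, read by MTT assay, with a stated time of 72 h (on this read-out higher numbers stand for weaker inhibition and lower numbers for stronger inhibition), can report: its value of > 64000 nM is a limit of the measurement, not a number (the limit of > 64000 nM in this assay, at which 1 of the 3 values shown sits). Compound 4 `O=C(CNc1ccc(Cl)cc1)N[C@H]1CCOC1=O` differs from it by hydrogen in place of chloro on an aromatic carbon. Going by the values given here, the only step with numbers on both sides lies elsewhere: compound 1 `O=C(COc1ccc(C(=O)/C=C/c2ccc(Cl)cc2Cl)cc1)N[C@H]1CCOC1=O` gives 8040 nM, compound 2 `COc1ccccc1/C=C/C(=O)c1ccc(OCC(=O)N[C@H]2CCOC2=O)cc1` gives 7240 nM, and a 1.1-fold lower number from compound 1 to compound 2 (0.05 log units; within the scatter) changes a different aryl group on a different core. Among the compounds with values here, no measured step therefore speaks to swapping a chloro for hydrogen here. Compound 4 is expected to remain near the limit, at 70000 nM with a range from 30000 nM to 150000 nM. That amounts to an expected step that the limit leaves unreadable from compound 3 to compound 4, nothing beyond the scatter.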

Compound 4, half-maximal inhibitory concentration: > 64000 nM
Compound 4: only a limit was reported; the forecaster's own chance of this, stated with the estimate: 75%; the middle value does not contradict the limit.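

Compound 3 and compound 4 both end at a limit of the measurement rather than a number, so no step can be read between them: the limit of > 64000 nM in this assay, at which 2 of the 4 values shown sit.

From the compounds shown here alone, whether hydrogen in place of chloro on the aromatic carbon changes the activity of this pair stays open.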